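Trifluoromethoxy to hydroxy: notes on growth inhibition

The source may report more compounds than this note shows. Statements on the series, on what has been measured and on what is new or still open speak of the compounds shown alone.

In a functional assay on HOP-62 cells (Homo sapiens) for inhibition, read by sulforhodamine B assay (on this read-out higher numbers stand for weaker inhibition of growth and lower numbers for stronger inhibition of growth), compound 2 (`Oc1cccc2[nH]c(-c3ccc(-c4ccc(-c5ccc(OC(F)(F)F)cc5)cc4)cc3)nc12`) gives 2270 nM, within the scatter of compound 1 (`Oc1cccc2[nH]c(-c3ccc(-c4ccc(-c5ccc(C(F)(F)F)cc5)cc4)cc3)nc12`) at 3200 nM. Compound 3 (`Oc1ccc(-c2ccc(-c3ccc(-c4nc5c(O)cccc5[nH]4)cc3)cc2)cc1`) differs from compound 2 as follows: hydrogen in place of trifluoromethyl on an oxygen on an aromatic ring. This places hydrogen in place of trifluoromethyl on an oxygen on an aromatic ring. For the measured compounds named here, the only measured step, a 1.4-fold lower number from compound 1 to compound 2 (0.15 log units; within the scatter), exchanges trifluoromethyl for trifluoromethoxy, so it offers weak guidance and no measured compound carries hydroxy. No shift beyond the scatter is therefore expected, in either direction, and the expected step is a 1.1-fold higher number from compound 2 to compound 3 (0.04 log units; within the scatter). For compound 3, the estimate is 2500 nM, with an expected range of 800 nM to 8000 nM.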

Compound 3, concentration for 50% growth inhibition: 2410 nM
Estimate against measurement, compound 3: 1.0-fold (0.02 log units) above; the measured number falls inside the stated range.
By their numbers in this assay, from the lowest: compounds 2, 3 and 1 (each within the scatter of the next).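

Hydrogen in place of trifluoromethyl on the oxygen gives a 1.1-fold higher number from compound 2 to compound 3 (0.03 log units; within the scatter) and hydroxy in place of trifluoromethyl on the aromatic carbon gives a 1.3-fold lower number from compound 1 to compound 3 (0.12 log units; within the scatter) in this assay as read here. Hydroxy, new to the series at this place, thus stands within the scatter of both fluorinated groups, so all three changes so far leave the read-out unresolved. No supporting evidence accompanies this result. Going by these compounds, whether an amine, a carboxylic acid or a longer chain at this place would move the number beyond the scatter stays open.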